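The compounds below may be only part of what the source reports. "The series", "measured", "known", "first", "only" and "open" are said of these compounds alone.

Compound 1 `COc1cc(OC)c(-c2coc3cc(OCC(=O)c4cccc(C(F)(F)F)c4)ccc3c2=O)cc1OC`: > 10000 nM
Compound 2 `COc1cc(OC)c(-c2coc3cc(OCc4ccccc4C(F)(F)F)ccc3c2=O)cc1OC`: > 10000 nM

In a functional assay on HUVEC cells (Homo sapiens) for antiproliferative activity, read by MTT assay, with a stated time of 24 h (a lower number here means a stronger inhibitor, a higher number a weaker inhibitor), compound 1 gives > 10000 nM, which is a limit of the assay and not a number. Compound 2 gives > 10000 nM, again only a limit. Neither compound therefore has a true number, as the limit of > 10000 nM in this assay, at which 2 of the 2 values shown sit, shows. Compound 3 `COc1cc(OC)c(-c2coc3cc(OCc4ccccc4C#N)ccc3c2=O)cc1OC` changes compound 2 in one place: cyano in place of trifluoromethyl on an aromatic carbon. Thus compound 3 carries a cyano group where compound 2 carries a trifluoromethyl group, ortho to a large group. For the measured compounds named here, the only measured step is a step that the two limits leave unreadable from compound 1 to compound 2, which has no readable size and concerns a different change. With nothing to suggest a gain, no shift beyond the usual scatter is expected in this assay. The expected change is a step that the limit leaves unreadable from compound 2 to compound 3. For compound 3 the estimated value is 15000 nM, with an expected range from 6000 nM to 40000 nM.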

Compound 3, half-maximal inhibitory concentration: > 10000 nM
Compound 3 gave a limit, no number; the forecaster's own chance of this, stated with the estimate: 85%; the middle value lies beyond the limit too.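

In this assay compound 3 gives > 10000 nM, a limit and not a number. No step among compound 1, compound 2 and compound 3 can be read, for one shared reason: the limit of > 10000 nM in this assay, at which 3 of the 3 values shown sit. On these data alone, how strong each of the three compounds truly is, and whether cyano in place of trifluoromethyl changes anything, stays open.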